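Closing the Acetamido into a Ring: Expected Potency

A few compounds are considered here, and "the series" means these few. Any claim that something is new, unique, unknown or untested is made for them only; others in the source may bear on it.

Measured so far:
Compound 1 `c1ccc2sc(Oc3ccc4c(CN5CCCCC5)coc4c3)nc2c1`: 420 nM
Compound 2 `CC(=O)NC1CCN(Cc2coc3cc(Oc4nc5ccccc5s4)ccc23)CC1`: 100 nM

In an assay on isolated protein (blood, strain CD1) for inhibition of leukotriene A-4 hydrolase (Mus musculus), read by immunoassay, with stated times of 15 min and 30 min (on this read-out higher numbers stand for weaker inhibition and lower numbers for stronger inhibition), compound 2 holds the lowest of the two numbers, and its gap to compound 1 is beyond the scatter. Compound 3 `O=C1CCCN1C1CCN(Cc2coc3cc(Oc4nc5ccccc5s4)ccc23)CC1` differs from compound 2 by 2-oxopyrrolidin-1-yl in place of acetamido on a saturated ring carbon. Within the data shown here, only one measured step bears on this position: a 4.2-fold lower number from compound 1 to compound 2 (0.62 log units; beyond the scatter), which shows that placing acetamido there lowers the number. Among the measured compounds shown here, no measured pair shows what the ring-closed group does in its place, so the step is expected to be small, most likely a modest move upward: a 1.6-fold higher number from compound 2 to compound 3 (0.20 log units; within the scatter). Compound 3 is therefore estimated at 160 nM, within 50 nM to 500 nM.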

Compound 3, half-maximal inhibitory concentration: 230 nM
Compound 3: the middle estimate sits 1.4-fold (0.16 log units) below what was measured; measured number inside the range.
By their numbers in this assay, from the lowest: compound 2; then compounds 3 and 1 (each within the scatter of the next).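

Replacing acetamido with 2-oxopyrrolidin-1-yl gives a 2.3-fold higher number from compound 2 to compound 3 (0.36 log units; beyond the scatter), so at this saturated ring carbon the ring-closed group does not match the open one. Compared with hydrogen at the same carbon, it gives a 1.8-fold lower number from compound 1 to compound 3 (0.26 log units; within the scatter), which leaves compound 3 and compound 1 indistinguishable on this read-out. Nothing available explains the difference between the two groups. The compounds shown leave open whether losing the amide hydrogen or adding the ring separates compound 2 from compound 3. They also leave open how an amine, a carboxylic acid or a longer chain would compare at this carbon.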